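Series notes: from compound 2 to compound 3

The source may hold more compounds than are shown below. What is called first, only, known or untested is meant among the compounds shown, and "the series" means these compounds.

Values in an ADME assay on WI-38 cells (Homo sapiens) for cytotoxicity, read by MTT assay, with a stated time of 72 h (a lower number here means a stronger inhibitor, a higher number a weaker inhibitor), follow
- compound 1 (`O=C(CCc1cccc2c1B(O)OC2)Nc1ccccc1`) gives 30000 nM
- compound 2 (`C#Cc1cccc(NC(=O)CCc2cccc3c2B(O)OC3)c1`) gives > 100000 nM (a limit)

Compound 2 stands at the limit of > 100000 nM in this assay, at which 1 of the 2 values shown sits, and this is a limit, not a number. Compound 3 (`O=C(CCc1cccc2c1B(O)OC2)Nc1cccc(-c2cccc(F)c2)c1`) carries 3-fluorophenyl in place of ethynyl on an aromatic carbon with 3-fluorophenyl in place of ethynyl. Among the measured compounds shown here, the one measured step bearing on this change is an at least 3.3-fold higher number from compound 1 to compound 2 (0.52 log units; beyond the scatter) and it lies beyond the scatter. With ethynyl gone, a move back towards compound 1 is expected, as compound 1 gives 30000 nM without that group. The expected change in this assay is an at least 2.5-fold lower number from compound 2 to compound 3 (0.39 log units; beyond the scatter) towards a lower number. For compound 3 the estimate is 40000 nM (expected range 10000 nM to 100000 nM).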

Compound 3, half-maximal inhibitory concentration: 37000 nM
For compound 3 the middle estimate is 1.1-fold (0.03 log units) above the measured one, within the range that was stated.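

For this aromatic carbon, this assay shows a 1.2-fold higher number from compound 1 to compound 3 (0.09 log units; within the scatter) with 3-fluorophenyl in place of hydrogen, so the higher number seen with ethynyl does not extend to every group placed here. Replacing ethynyl with 3-fluorophenyl gives an at least 2.7-fold lower number from compound 2 to compound 3 (0.43 log units; beyond the scatter) as the second step at this position. Compound 2 stands at a limit, not a number: the limit of > 100000 nM in this assay, at which 1 of the 3 values shown sits.

The compounds shown leave open how an amine or a carboxylic acid on this aromatic carbon would read. They also leave open whether the fluorine of 3-fluorophenyl plays any part in the number.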